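The compounds below may be only part of what the source reports. "The series", "measured", "known", "first", "only" and "open" are said of these compounds alone.

For the measured compounds named here, in a functional assay on HepG2 cells (Homo sapiens) for inhibition, read by MTT assay, with a stated time of 72 h (on this read-out lower numbers stand for stronger inhibition and higher numbers for weaker inhibition), compound 2 `Nc1ncnc2c1c(-c1cnc3[nH]ccc3c1)nn2CCCCCCCCC(=O)NO` gives 3050 nM, the only actual number so far. Compound 3 `Nc1ncnc2c1c(-c1cnc3[nH]ccc3c1)nn2CCC(=O)NO` differs from compound 2 by hydroxycarbamoyl in place of 6-(hydroxycarbamoyl)hexyl on a saturated chain carbon, two bonds along the chain from an aromatic nitrogen. Going by the values given here, no measured step covers this change. Compound 1 `Nc1ncnc2c1c(-c1cnc3[nH]ccc3c1)nn2CC(=O)NO`, also short-chained, reads > 150000 nM in this assay, which is a limit of the assay and not a number, and the expectation rests on it. The estimated weakening is large and beyond the scatter: a 20-fold higher number from compound 2 to compound 3 (1.29 log units; beyond the scatter). Compound 3 is expected at 60000 nM, within a range of 15000 nM to 150000 nM.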

Compound 3, half-maximal inhibitory concentration: > 150000 nM
Compound 3 gave a limit, no number; the forecaster's own chance of this, stated with the estimate: 50%; middle value at least 2.5-fold (0.39 log units) away from the limit.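

For the compounds shown here, replacing 6-(hydroxycarbamoyl)hexyl with hydroxycarbamoyl on this saturated chain carbon, two bonds along the chain from an aromatic nitrogen, gives the first readable step: an at least 49-fold higher number from compound 2 to compound 3 (1.69 log units; beyond the scatter). In this assay, going by these compounds alone, the only actual number therefore belongs to the long chain of compound 2. The step between compound 1 and compound 3 cannot be read, since both values are limits: the limit of > 150000 nM in this assay, at which 2 of the 3 values shown sit.

Open, from the compounds shown here alone, are chains of intermediate length between those of compound 3 and compound 2. Also open, going by these compounds, is whether a carboxylic acid in place of the hydroxycarbamoyl end of the long chain gives a readable number.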